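A few compounds are considered here, and "the series" means these few. Any claim that something is new, unique, unknown or untested is made for them only; others in the source may bear on it.

Of the compounds shown here, two that share one core have so far been tested in a functional assay on NCI-H520 cells (Homo sapiens); a higher number here means a weaker inhibitor of growth, a lower number a stronger inhibitor of growth. Compound 1 `O=S(=O)(/C=C/c1ccccc1)Cc1ccc(Nc2ncnc3ccccc23)cc1` gives > 100000 nM, which is a limit of the assay and not a number. Among the measured compounds shown here, compound 2 `O=S(=O)(/C=C/c1ccc(Cl)cc1)Cc1ccc(Nc2ncnc3ccccc23)cc1` gives 46000 nM, the only true number so far, so it has no measured neighbour to be ranked against by an exact margin.

Compound 3 `O=S(=O)(/C=C/c1ccc(C(F)(F)F)cc1F)Cc1ccc(Nc2ncnc3ccccc23)cc1` has not yet been measured in this assay. It carries 2-fluoro-4-(trifluoromethyl)phenyl in place of 4-chlorophenyl on a double-bonded chain carbon bound to a double-bonded chain carbon.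

For the measured compounds named here, only one measured step bears on this change, as it also alters that aromatic ring: an at least 2.1-fold lower number from compound 1 to compound 2 (0.33 log units; beyond the scatter), with chloro in place of hydrogen on an aromatic carbon. That single step from compound 1 to compound 2 sets no firm trend for a swap of one substituted ring for another, so only a small shift towards a lower number is expected, one that stays within the scatter. The estimated step is a 1.3-fold lower number from compound 2 to compound 3 (0.12 log units; within the scatter). For compound 3 the estimated value is 35000 nM, with an expected range from 10000 nM to 100000 nM.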

Compound 3, concentration for 50% growth inhibition: 100000 nM
Estimate against measurement, compound 3: 2.9-fold (0.46 log units) below, and the stated range covers the measured number.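

In this assay the change from 4-chlorophenyl to 2-fluoro-4-(trifluoromethyl)phenyl on a double-bonded chain carbon bound to a double-bonded chain carbon gives a 2.2-fold higher number from compound 2 to compound 3 (0.34 log units; beyond the scatter) and so this swap of one substituted ring for another is a modest step that can be told apart from ordinary scatter. Placing a substituent on this ring is therefore not enough in itself to give a lower number, as an at least 2.1-fold lower number from compound 1 to compound 2 (0.33 log units; beyond the scatter) might have suggested; which groups the ring carries makes a difference. The value of compound 1 is a limit: the limit of > 100000 nM in this assay, at which 1 of the 3 values shown sits.
What remains is a number no higher from compound 1 to compound 3 (the limit leaves the size open) and that step cannot be read.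

Compound 3 differs from compound 2 by the loss of chloro and the gain of both fluoro and trifluoromethyl, so the compounds shown cannot assign the step to any one of these groups. Rings carrying only a 4-trifluoromethyl or only a 2-fluoro group would separate those contributions, while a 4-methoxyphenyl or 4-aminophenyl ring at the same place would show how groups built on oxygen or nitrogen compare.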